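Nitro for Trifluoromethyl on the Anilino Ring of Compound 3

A few compounds are considered here, and "the series" means these few. Any claim that something is new, unique, unknown or untested is made for them only; others in the source may bear on it.

Among the measured compounds shown here, compound 3 `FC(F)(F)c1ccc(CSc2nc(Nc3cccc(C(F)(F)F)c3)c3ccccc3n2)cc1` stands lowest of the three numbers so far in a functional assay on MDA-MB-231 cells (Homo sapiens) for cytotoxicity, read by MTT assay, with a stated time of 72 h (a lower number here means a stronger inhibitor, a higher number a weaker inhibitor), where compound 3 gives 11100 nM. Compound 2 `Cc1ccccc1Nc1nc(SCc2ccc(C(F)(F)F)cc2)nc2ccccc12` gives 27100 nM in this assay, and compound 1 `FC(F)(F)c1ccc(CSc2nc(N3CCCCC3)c3ccccc3n2)cc1` gives 28400 nM. The step of a 2.4-fold lower number from compound 2 to compound 3 (0.39 log units; beyond the scatter) and the step of a 2.6-fold lower number from compound 1 to compound 3 (0.41 log units; beyond the scatter) both lie beyond the scatter, while a 1.0-fold lower number from compound 1 to compound 2 (0.02 log units; within the scatter) lies within it.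

Compound 4 `O=[N+]([O-])c1cccc(Nc2nc(SCc3ccc(C(F)(F)F)cc3)nc3ccccc23)c1` differs from compound 3 in one place: nitro in place of trifluoromethyl on an aromatic carbon. For the measured compounds named here, none of the measured steps exchanges one substituent for another on the same phenyl ring, so no step bears on this change directly. The nearest guide is a 2.4-fold lower number from compound 2 to compound 3 (0.39 log units; beyond the scatter), a modest step that came with a change of the whole substituted phenyl group. Every step measured so far has been modest or within the scatter, and the same is expected here. Compound 4 is expected to show a step of a 1.1-fold higher number from compound 3 to compound 4 (0.03 log units; within the scatter), which is small, in either direction or none beyond the scatter. Compound 4 is therefore estimated in this assay at 12000 nM, with a range from 5000 nM to 30000 nM.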

Compound 4, half-maximal inhibitory concentration: 31500 nM
Compound 4: middle estimate off by 2.6-fold (0.42 log units), on the low side; the measured number lies above the stated range.
By their numbers in this assay, from the lowest: compound 3; then compounds 2, 1 and 4 (each within the scatter of the next).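

In this assay, among the compounds shown here, the exchange of trifluoromethyl for nitro on this aromatic carbon, meta to a large group, is the first change measured within one substituted phenyl ring, and it is not neutral: there is a 2.8-fold higher number from compound 3 to compound 4 (0.45 log units; beyond the scatter) in this single exchange, a step of about the same size as those that first set compound 3 apart. The other two new steps, a 1.2-fold higher number from compound 2 to compound 4 (0.07 log units; within the scatter) and a 1.1-fold higher number from compound 1 to compound 4 (0.04 log units; within the scatter), both lie within the scatter, so (3-nitrophenyl)amino does not separate from (2-methylphenyl)amino or piperidin-1-yl here, and compound 3 alone, with steps beyond the scatter to all three others, is the strongest inhibitor of the four, which ties its standing to the trifluoromethyl group rather than to the anilino nitrogen alone. Nothing shown here gives a measured reason for this difference between trifluoromethyl and nitro. As far as these compounds go, whether a nitrile, a carboxylic acid, an amine or a longer chain on this same carbon would stand with compound 3 or with compound 4 remains open. Also open, from the compounds shown here alone, is whether the exchange of trifluoromethyl for nitro would give a step of similar size if the rest of compound 3 were changed elsewhere.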